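The compounds below may be only part of what the source reports. "The series", "measured", "known", "first", "only" and "open" are said of these compounds alone.

Series notes, an assay on HeLa cells for inhibition of histone-lysine N-methyltransferase EZH2 (Homo sapiens), read by AlphaLISA, with a stated time of 72 h; on this read-out higher numbers stand for an effect only at larger amounts of compound and lower numbers for an effect already at smaller amounts.

Among the compounds with values here, compound 1 `COc1cc(C)[nH]c(=O)c1CNC(=O)c1c(C)n([C@H](C)C2CCN(C(=O)N(C)C)CC2)c2ccccc12` gives 930 nM in this assay, the highest of the three numbers measured so far. Compound 2 `CCS(=O)(=O)N1CCC([C@@H](C)n2c(C)c(C(=O)NCc3c(OC)cc(C)[nH]c3=O)c3ccccc32)CC1` gives 80 nM, and compound 3 `COc1cc(C)[nH]c(=O)c1CNC(=O)c1c(C)n([C@H](C)C2CCN(C(=O)C(C)C)CC2)c2ccccc12` gives 420 nM. Both measured steps away from compound 1 lower the number: a 12-fold lower number from compound 1 to compound 2 (1.07 log units; beyond the scatter) and a 2.2-fold lower number from compound 1 to compound 3 (0.35 log units; beyond the scatter). Between those two replacements, a 5.3-fold higher number from compound 2 to compound 3 (0.72 log units; beyond the scatter).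

Compound 4 `CCOC(=O)CN1CCC([C@@H](C)n2c(C)c(C(=O)NCc3c(OC)cc(C)[nH]c3=O)c3ccccc32)CC1` is not yet measured. It differs from compound 1 in one place: (ethoxycarbonyl)methyl in place of dimethylcarbamoyl on an amine nitrogen in a ring. The dimethylcarbamoyl leaves and (ethoxycarbonyl)methyl enters, on an amine nitrogen in a ring of a six-membered non-aromatic ring with 1 nitrogen. Within the data shown here, no measured step brings in this group; the ethylsulfonyl of compound 2 and the isopropylcarbonyl of compound 3 are the only exchanges tried at that nitrogen, and each gave a lower number than compound 1. Among the measured compounds shown here, the step to compound 4 has no close precedent, and what the measured steps show is only that the dimethylcarbamoyl can be exchanged at this nitrogen without the number rising. A modest lowering, or no step beyond the scatter, is expected, and the expected step is a 1.7-fold lower number from compound 1 to compound 4 (0.23 log units; within the scatter). Compound 4 is estimated at 550 nM, with a range from 150 nM to 2000 nM.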

Compound 4, half-maximal effective concentration: 260 nM
The estimate for compound 4 lay 2.1-fold (0.33 log units) above the measured number, within the range that was stated.
By their numbers in this assay, from the lowest: compound 2; then compounds 4 and 3 (each within the scatter of the next); then compound 1.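

In this assay, a 3.6-fold lower number from compound 1 to compound 4 (0.55 log units; beyond the scatter), so a third replacement of the dimethylcarbamoyl on this amine nitrogen in a ring also lowers the number, and this time the entering group places neither a carbonyl nor a sulfonyl directly on that nitrogen, as the groups in compounds 1, 2 and 3 do. Among the replacements, a 1.6-fold lower number from compound 3 to compound 4 (0.21 log units; within the scatter), which gives no order between the (ethoxycarbonyl)methyl and the isopropylcarbonyl, whereas a 3.3-fold higher number from compound 2 to compound 4 (0.51 log units; beyond the scatter), leaving the ethylsulfonyl of compound 2 with the lowest number of the four compounds. No supporting data bear on why these groups at this nitrogen differ.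

It remains open whether the ester of compound 4 matters, since neither the carboxylic acid formed by replacing its ethyl with hydrogen nor a plain ethyl group on the ring nitrogen is among these compounds. Also open, on these data alone, is whether a longer chain on the sulfonyl, such as propylsulfonyl, or a cyclopropylsulfonyl group would keep or further lower the number of compound 2.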